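This account rests on a few compounds, and the source may have more. Where it says the series, first, only, none or still open, it means among the compounds named here.

Measured compounds:
Compound 1, `COc1ccc(-c2nc3cc(C(F)(F)F)ccc3[nH]2)c(N)c1`, gives in an ADME assay on BHK cells (Mesocricetus auratus) for cytotoxicity, read by MTT assay, with a stated time of 96 h (on this read-out lower numbers stand for higher toxicity in this test and higher numbers for lower toxicity in this test), a value of >= 100000 nM.
Compound 2, `CCN(CC)CC(=O)Nc1ccc(-c2nc3cc(C(F)(F)F)ccc3n2C)cc1`, gives in this assay a value of 16000 nM.
Compound 3, `COc1ccc(-c2nc3cc(C(C)=O)ccc3[nH]2)c(OC)c1OC`, gives in this assay a value of > 100000 nM.

Compound 3 stands at the limit of > 100000 nM in this assay, at which 1 of the 3 values shown sits, which is a limit of the measurement and not a number. Compound 1 also stands at a limit, (the limit of >= 100000 nM in this assay, at which 1 of the 3 values shown sits). Among the measured compounds shown here, only compound 2 yields an actual number, so no step between measured compounds can be sized.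

Compound 4, `COc1ccc(-c2nc3cc(C(C)=O)ccc3[nH]2)c(OC)c1`, differs from compound 3 by hydrogen in place of methoxy on an aromatic carbon. For the measured compounds named here, no measured step speaks to this change. The step of a number no higher from compound 3 to compound 4 (the limit leaves the size open) is expected to be none beyond the usual scatter. Compound 4 is therefore estimated at 100000 nM, with a range from 40000 nM to 250000 nM, and most likely again reported only as a limit.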

Compound 4, half-maximal cytotoxic concentration: > 100000 nM
Compound 4: only a limit was reported; the forecaster's own chance of this, stated with the estimate: 70%; the middle value lies on the limit itself.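

Compound 3 and compound 4 both stand at a limit of the measurement and not at a number, so no step between them can be read: the limit of > 100000 nM in this assay, at which 2 of the 4 values shown sit.

The compounds shown leave open whether hydrogen in place of methoxy changes the result in this assay at all.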